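Lipophilicity notes: amide cap exchange on a shared core

The source may hold more compounds than are shown below. What is called first, only, known or untested is meant among the compounds shown, and "the series" means these compounds.

Measured so far:
compound 1 `CCCC(=O)NCCCCCC(=O)N[C@H](C(=O)N1C[C@H](O)C[C@H]1C(=O)NCc1ccc(-c2scnc2C)cc1)C(C)(C)C` — 2.2
compound 2 `Cc1ncsc1-c1ccc(CNC(=O)[C@@H]2C[C@@H](O)CN2C(=O)[C@@H](NC(=O)CCCCCOC(=O)CC(c2ccccc2)c2ccccc2)C(C)(C)C)cc1` — 1.9

In a physicochemical assay for lipophilicity, read by LC-MS, using the shake flask method, in phosphate buffer, with a stated time of 50 min, at pH 7.4 (on this read-out higher numbers stand for higher lipophilicity and lower numbers for lower lipophilicity), compound 1 gives 2.2 and compound 2 gives 1.9. For the measured compounds named here, the gap between these two numbers lies within the scatter, so neither compound can be set apart from the other on this read-out, and no step between them is available for comparison.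

Compound 3 `Cc1ncsc1-c1ccc(CNC(=O)[C@@H]2C[C@@H](O)CN2C(=O)[C@@H](NC(=O)CCCCCNC(=O)C2CCCCC2)C(C)(C)C)cc1` is not yet measured. Relative to compound 1 it carries the following change: cyclohexyl in place of propyl on a carbonyl carbon. Three carbon atoms and a six-membered non-aromatic ring of carbon only enter on the carbonyl carbon, with no change in donor or acceptor count and no charge.

From the size of the group entering, the step from compound 1 to compound 3 in this assay is expected to be a number 0.90 log units higher from compound 1 to compound 3 (beyond the scatter), upward and beyond the scatter. Compound 3 is accordingly estimated at 3.1, within 2.6 to 3.6.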

Compound 3, distribution coefficient: 1.4
Beside the measured number, compound 3's estimate is 1.70 log units above it; measured number below the stated range.
By their numbers in this assay, from the lowest: compound 3; then compounds 2 and 1 (each within the scatter of the next).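

In this assay, for the compounds shown here, the exchange of propyl for cyclohexyl on a carbonyl carbon gives a number 0.80 log units lower from compound 1 to compound 3 (beyond the scatter), the first readable step, and it shows that the read-out responds to a change at this position. The direction runs against the count of atoms: cyclohexyl brings more carbon and a six-membered non-aromatic ring, with hydrogen-bond donors, acceptors and net charge unchanged, yet the number falls. Nothing measured on these compounds accounts for the fall.

As far as these compounds go, a single step cannot separate ring closure from the number of carbon atoms, so it remains open whether the fall is particular to cyclohexyl. Cyclopropyl, phenyl, an open hexyl chain or a cap bearing an amine on the same carbonyl carbon would each bear on that question.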